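Trifluoromethyl ether in place of sec-butyl ether: notes

The source may hold more compounds than are shown below. What is called first, only, known or untested is meant among the compounds shown, and "the series" means these compounds.

Measured so far, each in a functional assay on CHO cells with sphingosine 1-phosphate receptor 2 (Homo sapiens) as the target, read by GTPgammaS binding; a lower number here means that less compound is needed, a higher number that more compound is needed for the effect:
- compound 1, `COc1cc(-c2nc(-c3ccc(CCC(=O)O)cc3C)no2)ccc1OC(C)C`, gives > 10000 nM, a limit of the assay and not a number.
- compound 2, `Cc1cc(CCC(=O)O)ccc1-c1noc(-c2ccc(OC(C)C)c(C#N)c2)n1`, gives > 10000 nM, again only a limit.
- compound 3, `CC[C@H](C)Oc1ccc(-c2nc(-c3ccc(CCC(=O)O)cc3C)no2)cc1C#N`, gives > 10000 nM, again only a limit.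

Compound 3 therefore stands nowhere on a scale: in this assay its result is a limit, and the same holds for every other value shown, as the limit of > 10000 nM in this assay, at which 3 of the 3 values shown sit, records. The two steps that connect the measured compounds, a step that the two limits leave unreadable from compound 1 to compound 2 and a step that the two limits leave unreadable from compound 2 to compound 3, are both unreadable for this reason; neither gives a size or a direction.

Compound 4, `Cc1cc(CCC(=O)O)ccc1-c1noc(-c2ccc(OC(C)C(F)(F)F)c(C#N)c2)n1`, differs from compound 3 by 1-(trifluoromethyl)ethyl in place of sec-butyl on an oxygen on an aromatic ring. For the measured compounds named here, no measured step bears on this change: the only variations seen so far at this oxygen and at the neighbouring aromatic carbon all ended at the limit, so nothing shows whether any change here moves the read-out at all.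

The expectation for compound 4 rests on that alone: since compound 3 and its relatives all sit at the limit (the limit of > 10000 nM in this assay, at which 3 of the 3 values shown sit), compound 4 is most likely expected to sit there too, with the step that the limit leaves unreadable from compound 3 to compound 4 treated as unreadable. The estimate for compound 4 in this assay is 15000 nM, within a range from 3000 nM to 60000 nM.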

Compound 4, half-maximal effective concentration: > 10000 nM
Compound 4 was reported as a limit (the forecaster's own chance of this, stated with the estimate: 80%); the middle value is on the limit's open side.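

Compound 4 adds no readable step: its comparisons with compound 2 and compound 3 in this assay cannot be read, because each of these results is only a limit: the limit of > 10000 nM in this assay, at which 4 of the 4 values shown sit.

The compounds shown leave open whether any of these changes moves the read-out at all, and in which direction.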